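Swapping a Bromophenyl for a Hydroxy-Methoxyphenyl Group

A few compounds are considered here, and "the series" means these few. Any claim that something is new, unique, unknown or untested is made for them only; others in the source may bear on it.

Measured compounds:
compound 1 `COc1ccc(CN(C(=O)CSC(=S)N2CCOCC2)c2cc(OC)c(OC)c(OC)c2)cc1`: 2370 nM
compound 2 `COc1cc(N(Cc2ccc(Br)cc2)C(=O)CSC(=S)N2CCN(C(=O)OC(C)(C)C)CC2)cc(OC)c1OC`: 12400 nM

Of the compounds shown here, two have been measured in a functional assay on MGC-803 cells (Homo sapiens) for inhibition, read by CCK-8 assay, with a stated time of 48 h; on this read-out higher numbers stand for weaker inhibition and lower numbers for stronger inhibition. Compound 1 gives 2370 nM, while compound 2 gives 12400 nM, the higher of the two numbers and therefore the weaker inhibitor; the gap between them lies beyond the usual scatter.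

Compound 3 `COc1ccc(CN(C(=O)CSC(=S)N2CCN(C(=O)OC(C)(C)C)CC2)c2cc(OC)c(OC)c(OC)c2)cc1O` has not yet been measured. It differs from compound 2 in one place: 3-hydroxy-4-methoxyphenyl in place of 4-bromophenyl on a saturated chain carbon bound to an amide-type nitrogen. The rest of the molecule, including the shared core and the dithiocarbamate-linked piperazine, is unchanged.

Among the measured compounds shown here, with no measured pair showing this kind of change, the step is uncertain. A modest move toward a lower number, roughly at the edge of the scatter, is expected for a 2.1-fold lower number from compound 2 to compound 3 (0.32 log units; beyond the scatter). For compound 3, the estimated value in this assay is 6000 nM, within a range of 1500 nM to 20000 nM.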

Compound 3, half-maximal inhibitory concentration: 82 nM
Estimate against measurement, compound 3: 73-fold (1.86 log units) above; the whole stated range lies above it.
By their numbers in this assay, from the lowest: compound 3; then compound 1; then compound 2.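

In this assay the exchange of 4-bromophenyl for 3-hydroxy-4-methoxyphenyl on a saturated chain carbon bound to an amide-type nitrogen gives a 150-fold lower number from compound 2 to compound 3 (2.18 log units; beyond the scatter) with the rest of the molecule unchanged. Among the compounds shown here, this is the first single-place comparison, and it shows that the number in this cell assay depends strongly on the aromatic group at this position. No evidence shown accounts for the size of this step.

The exchange removes the bromine and adds the hydroxy and methoxy groups in one move, so the compounds shown cannot tell which of these changes matters. From the compounds shown here alone, it also remains open whether an amino group in place of the hydroxy group, or a carboxylic acid on the ring, would give a similar number.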